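This account rests on a few compounds, and the source may have more. Where it says the series, first, only, none or still open, it means among the compounds named here.

Measured so far:
compound 1 `COc1cc(-c2nn(-c3cccc(NC(=O)c4cccc(C(F)(F)F)c4)c3)cc2-c2ccncc2)ccc1Cl`: 1450 nM
compound 2 `COc1cc(-c2nn(-c3cccc(NC(=O)Nc4cccc(C(F)(F)F)c4)c3)cc2-c2ccncc2)ccc1Cl`: 763 nM
compound 3 `O=C(Nc1cccc(-n2cc(-c3ccncc3)c(-c3ccc(Cl)c(O)c3)n2)c1)Nc1cc(C(F)(F)F)cc(C(F)(F)F)c1`: 413 nM

In a functional assay on NCI-H460 cells (Homo sapiens) for inhibition, read by sulforhodamine B assay, with a stated time of 48 h (a lower number here means a stronger inhibitor of growth, a higher number a weaker inhibitor of growth), compound 1 gives the highest of the three numbers; compound 2 sits a step away that is within the scatter, while compound 3 sits beyond it. Compound 4 `COc1cc(-c2nn(-c3cccc(NC(=O)Nc4ccc(Cl)c(C(F)(F)F)c4)c3)cc2-c2ccncc2)ccc1Cl` differs from compound 1 in one place: (4-chloro-3-(trifluoromethyl)phenyl)amino in place of 3-(trifluoromethyl)phenyl on a carbonyl carbon. Within the data shown here, the only measured step that bears on this change is a 1.9-fold lower number from compound 1 to compound 2 (0.28 log units; within the scatter), where a (3-(trifluoromethyl)phenyl)amino group entered at the same carbonyl carbon. Among the measured compounds shown here, the added chlorine has no measured counterpart; compound 3, which carries a different amino-linked ring and differs elsewhere as well, gives 413 nM. A modest move to a lower number is therefore expected for compound 4, a 2.4-fold lower number from compound 1 to compound 4 (0.38 log units; beyond the scatter). Compound 4 is estimated at 600 nM, with a range from 250 nM to 1500 nM.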

Compound 4, concentration for 50% growth inhibition: 1110 nM
Compound 4: middle estimate off by 1.9-fold (0.27 log units), on the low side, within the range that was stated.
By their numbers in this assay, from the lowest: compounds 3, 2, 4 and 1 (each within the scatter of the next, the first and the last beyond it).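

In this assay, the full replacement on the carbonyl carbon gives a step within the scatter (a 1.3-fold lower number from compound 1 to compound 4 (0.12 log units; within the scatter)), and so does chloro in place of hydrogen on an aromatic carbon (a 1.5-fold higher number from compound 2 to compound 4 (0.16 log units; within the scatter)). Compound 4 thus shows that this ring can carry the chloro without a step beyond the scatter from either compound 1 or compound 2. No measurement shown accounts for these numbers. As far as these compounds go, whether a bromo, methyl or nitrile group in place of that chloro would give a step beyond the scatter remains open.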